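The source may hold more compounds than are shown below. What is called first, only, known or untested is meant among the compounds shown, and "the series" means these compounds.

Compound 1 `CCOC(=O)c1ccc2oc(NC(CC3CCCCC3)c3ccccc3)nc2c1`: 45 nM
Compound 2 `CN(C)C(=O)c1ccc2oc(NC(CC3CCCCC3)c3ccccc3)nc2c1`: 170 nM
Compound 3 `N#Cc1ccc2oc(NC(CC3CCCCC3)c3ccccc3)nc2c1`: 15 nM

In a functional assay for inhibition, with Homo sapiens as the target (on this read-out higher numbers stand for weaker inhibition and lower numbers for stronger inhibition), compound 3 has the lowest of the three numbers, making it the strongest inhibitor so far. Compound 4 `CC(=O)Nc1ccc2oc(NC(CC3CCCCC3)c3ccccc3)nc2c1` has acetamido in place of cyano on an aromatic carbon.

Among the measured compounds shown here, no measured step makes this exact swap. The closest guides are two steps that end in the cyano group: a 3.0-fold lower number from compound 1 to compound 3 (0.48 log units; beyond the scatter) and an 11-fold lower number from compound 2 to compound 3 (1.05 log units; beyond the scatter). In both, a carbonyl-bearing group gives way to cyano and the number falls. Acetamido also bears a carbonyl, so a rise of similar size is expected on leaving cyano, though this remains uncertain.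

The expected step is a 6.7-fold higher number from compound 3 to compound 4 (0.82 log units; beyond the scatter). For compound 4, the estimated value is 100 nM, with an expected range of 25 nM to 400 nM.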

Compound 4, half-maximal inhibitory concentration: 78 nM
Compound 4: the middle estimate sits 1.3-fold (0.11 log units) above what was measured, within the range that was stated.
By their numbers in this assay, from the lowest: compound 3; then compounds 1 and 4 (each within the scatter of the next); then compound 2.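

In this assay acetamido, which brings a hydrogen-bond donor to this aromatic carbon, does not match cyano, with a 5.2-fold higher number from compound 3 to compound 4 (0.72 log units; beyond the scatter) here. Acetamido and ethoxycarbonyl cannot be told apart, since a 1.7-fold higher number from compound 1 to compound 4 (0.24 log units; within the scatter) is no real difference, while a 2.2-fold lower number from compound 2 to compound 4 (0.34 log units; beyond the scatter) shows that groups bearing a carbonyl do not all give the same number at this position. Nothing available explains these differences.

Going by these compounds, whether an amine or a carboxylic acid at this position would come close to cyano stays open. So does the effect of a longer chain in place of the acetyl part of acetamido.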